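A few compounds are considered here, and "the series" means these few. Any claim that something is new, unique, unknown or untested is made for them only; others in the source may bear on it.

Of the compounds shown here, three with a shared core have been measured so far. Compound 1 `Cc1cc(Nc2cc(-c3ccccc3)[nH]n2)n2nc(SCc3csc4ccccc34)nc2n1`, tested in a functional assay on MGC-803 cells (Homo sapiens) for inhibition, read by MTT assay, with a stated time of 72 h (on this read-out higher numbers stand for weaker inhibition and lower numbers for stronger inhibition), gives 2280 nM. Compound 2 `Cc1cc(Nc2cc(-c3cccs3)[nH]n2)n2nc(SCc3ccc(Br)cc3)nc2n1` gives 3770 nM in this assay, and compound 3 `Cc1cc(Nc2ccn(Cc3ccc(F)cc3)n2)n2nc(SCc3ccc(Br)cc3)nc2n1` gives 3070 nM. Compound 1 has the lowest number of the three, yet its gaps to compound 3 and to compound 2 both fall inside the usual scatter of repeated measurements, so the three values cannot be told apart with confidence, and none of the three can be called the strongest or weakest.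

Compound 4 `C#CCSc1nc2nc(C)cc(Nc3cc(-c4ccccc4)[nH]n3)n2n1` has not yet been measured. It differs from compound 1 in one place: ethynyl in place of 1-benzothiophen-3-yl on a saturated chain carbon bound to a sulfur. A group of nine heavy atoms with two aromatic rings is thus exchanged for a short two-carbon group carrying a triple bond, at the sulfur-bound chain carbon.

Going by the values given here, no pair of measured compounds differs in a single place, so no measured step exists to show how this kind of change moves the read-out. With nothing to anchor it, the expectation from compound 1 to compound 4 is a step of a 2.4-fold higher number from compound 1 to compound 4 (0.38 log units; beyond the scatter) toward weaker inhibition, of a size only modestly beyond the scatter. On that basis compound 4 is estimated to give about 5500 nM in this assay, with a plausible range from 1800 nM to 17000 nM.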

Compound 4, half-maximal inhibitory concentration: 13400 nM
Beside the measured number, compound 4's estimate is 2.4-fold (0.39 log units) below it; measured number inside the range.
By their numbers in this assay, from the lowest: compounds 1, 3 and 2 (each within the scatter of the next); then compound 4.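

In this assay, exchanging 1-benzothiophen-3-yl for ethynyl on a saturated chain carbon bound to a sulfur gives a 5.9-fold higher number from compound 1 to compound 4 (0.77 log units; beyond the scatter) and moves the read-out toward weaker inhibition. The three earlier compounds could not show this: none of them differs from another in a single place, and their numbers all lie within the scatter of one another. This step is therefore the first direct sign that the group at this position matters, and the change from a group with two aromatic rings to a short group with a triple bond is one that this read-out registers, though no measured finding here explains why the number moves.

A single step also cannot separate the loss of the two aromatic rings from the arrival of the triple bond, so an ethyl group or a phenyl ring in the same place would be needed to tell these apart. As far as these compounds go, whether the same exchange has a similar effect on compounds with a different group on the other side of the shared core also remains open.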